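Replacing the 3-cyanophenyl group of compound 3

This account rests on a few compounds, and the source may have more. Where it says the series, first, only, none or still open, it means among the compounds named here.

In a functional assay on MCF7 cells (Homo sapiens) for cytotoxicity, read by CellTiter-Glo, with a stated time of 5 days (on this read-out lower numbers stand for stronger inhibition and higher numbers for weaker inhibition), compound 1 `CC/C(=C(/c1ccc(/C=C/C(=O)O)cc1)c1ccc2[nH]ncc2c1)c1ccccc1Cl` gives 2 nM, compound 2 `CC/C(=C(/c1ccc(/C=C/C(=O)O)cc1)c1ccc2[nH]ncc2c1)c1cccc(Cl)c1` gives 12 nM, and compound 3 `CC/C(=C(/c1ccc(/C=C/C(=O)O)cc1)c1ccc2[nH]ncc2c1)c1cccc(C#N)c1` gives 100 nM, the highest of the three numbers. Compound 4 `CC/C(=C(/c1ccc(/C=C/C(=O)O)cc1)c1ccc2[nH]ncc2c1)c1ccccc1OC` differs from compound 3 in one place: 2-methoxyphenyl in place of 3-cyanophenyl on a double-bonded chain carbon bound to a double-bonded chain carbon and a saturated chain carbon. For the measured compounds named here, three measured steps bear on this. Exchanging 2-chlorophenyl for 3-cyanophenyl gave a 50-fold higher number from compound 1 to compound 3 (1.70 log units; beyond the scatter), exchanging it for 3-chlorophenyl gave a 6.0-fold higher number from compound 1 to compound 2 (0.78 log units; beyond the scatter), and cyano in place of chloro gave an 8.3-fold higher number from compound 2 to compound 3 (0.92 log units; beyond the scatter). No methoxy group has been measured, so the expectation rests on the shared 2-substitution with compound 1 at 2 nM. The estimated change is large and downward, a 17-fold lower number from compound 3 to compound 4 (1.22 log units; beyond the scatter). Compound 4 is expected near 6 nM, within an estimated range of 1.5 nM to 30 nM.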

Compound 4, half-maximal inhibitory concentration: 25 nM
For compound 4 the middle estimate is 4.2-fold (0.62 log units) below the measured one, within the range that was stated.
By their numbers in this assay, from the lowest: compound 1; then compound 2; then compound 4; then compound 3.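

In this assay 2-methoxyphenyl in place of 3-cyanophenyl gives a 4.0-fold lower number from compound 3 to compound 4 (0.60 log units; beyond the scatter) and so improves on the nitrile without approaching the chloro compounds. Methoxy in place of chloro gives a 13-fold higher number from compound 1 to compound 4 (1.10 log units; beyond the scatter) and 2-methoxyphenyl in place of 3-chlorophenyl gives a 2.1-fold higher number from compound 2 to compound 4 (0.32 log units; beyond the scatter) so the lead of 2-chlorophenyl does not extend to every group named as 2-substituted here. The compounds shown leave open how 3-methoxyphenyl or 2-cyanophenyl would compare, which would separate the effect of the group from that of its place on the ring. No measurement offered here explains these differences.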